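Replacing the amino group of compound 1 with phenethylsulfanyl

The source may hold more compounds than are shown below. What is called first, only, known or untested is meant among the compounds shown, and "the series" means these compounds.

Compound 1 `Nc1nc(=O)ccn1[C@@H]1O[C@H](COP(=O)(O)O)[C@@H](O)[C@H]1O` is the anchor of this small set. Among the measured compounds shown here, in an in vitro functional assay on 1321-N1 cells for agonist activity at P2Y purinoceptor 4 (Homo sapiens), read by scintillation proximity assay and inositol phosphate accumulation (a higher number here means that more compound is needed for the effect, a lower number that less compound is needed), compound 1 gives 4980 nM, the only actual number among the three values shown. Compound 2 and compound 3 stop at limits of the assay.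

Compound 3 `COc1nc(=O)ccn1[C@@H]1O[C@H](COP(=O)(O)O)[C@@H](O)[C@H]1O` reaches only a limit, > 100000 nM. For the measured compounds named here, the one measured step that bears on the present question is an at least 20-fold higher number from compound 1 to compound 3 (1.30 log units; beyond the scatter), a change of methoxy in place of amino on an aromatic carbon, which carries the activity out to the limit of > 100000 nM in this assay, at which 1 of the 3 values shown sits.

Compound 2 `O=c1ccn([C@@H]2O[C@H](COP(=O)(O)OP(=O)(O)O)[C@@H](O)[C@H]2O)c(SCCc2ccccc2)n1` also stops at a limit, >= 100000 nM. Going by the values given here, compound 2 already carries the phenethylsulfanyl group, though on a different phosphate chain, so no single-point step to compound 1 can be drawn from it.

Compound 4 `O=c1ccn([C@@H]2O[C@H](COP(=O)(O)O)[C@@H](O)[C@H]2O)c(SCCc2ccccc2)n1` is the compound still to be measured. It differs from compound 1 by phenethylsulfanyl in place of amino on an aromatic carbon.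

Since the smaller swap from compound 1 to compound 3 already pushed the value past the limit, the loss of the amino group in compound 4 is expected to behave similarly, and the step of a 20-fold higher number from compound 1 to compound 4 (1.30 log units; beyond the scatter) is estimated to be large and upward. Compound 4 is therefore expected to give about 100000 nM, within a range of 20000 nM to 500000 nM, most likely reported only as a limit.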

Compound 4, half-maximal effective concentration: > 100000 nM
Compound 4 was reported as a limit (the forecaster's own chance of this, stated with the estimate: 70%); the middle value lies on the limit itself.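

In this assay, the amino group of compound 1 has now been replaced at this position by two different groups, methoxy and phenethylsulfanyl, and both changes end at a limit: an at least 20-fold higher number from compound 1 to compound 4 (1.30 log units; beyond the scatter) now stands alongside an at least 20-fold higher number from compound 1 to compound 3 (1.30 log units; beyond the scatter). The loss of a measurable value at this position is therefore not peculiar to methoxy, and it also appears with a much larger group that brings an aromatic ring and has no hydrogen-bond donor. Compound 4 gives a limit and not a number: the limit of > 100000 nM in this assay, at which 2 of the 4 values shown sit.

The steps from compound 3 and from compound 2 to compound 4 cannot be read, as both ends of each step are limits. The compounds shown leave open how far past the limit compound 3 and compound 4 lie, so methoxy and phenethylsulfanyl cannot be ranked against each other. They also leave open whether a methylamino or dimethylamino group on this carbon, or a triphosphate chain on the core of compound 1, would give a measurable value.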